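Replacing a pyridinylmethylamine arm with a tetrahydropyranylamine

The source may hold more compounds than are shown below. What is called first, only, known or untested is meant among the compounds shown, and "the series" means these compounds.

Of the compounds shown here, two sharing the same core have been measured in a functional assay on cells for antagonist activity at C-X-C chemokine receptor type 4 (Homo sapiens), read by fluorescence and calcium flux, with stated times of 25 min and 90 s; a higher number here means a weaker inhibitor, a lower number a stronger inhibitor. Compound 1 `c1ccc(CN(CCCCN(C[C@H]2Cc3ccccc3CN2)[C@H]2CCCc3cccnc32)Cc2ccccn2)nc1` gives 664 nM in this assay. Compound 2 `c1ccc2c(c1)CN[C@@H](CN(CCCCNCc1ccncc1)[C@H]1CCCc3cccnc31)C2` gives 22.7 nM in this assay, the lower of the two numbers; the number for compound 1 is higher by a margin that lies beyond the usual scatter, so compound 2 is the stronger inhibitor of the pair.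

Compound 3 `CC(C)(CCN(C[C@H]1Cc2ccccc2CN1)[C@H]1CCCc2cccnc21)CNC1CCOCC1` has not yet been measured. Relative to compound 2, the difference is a group of 11 heavy atoms (9 carbon, 1 nitrogen, 1 oxygen; one six-membered non-aromatic ring with 1 hetero atom) in place of a group of 10 heavy atoms (8 carbon, 2 nitrogen; one six-membered aromatic ring with 1 hetero atom), on a saturated chain carbon, two bonds along the chain from an amine nitrogen. For the measured compounds named here, no step between measured compounds covers a change of this kind, so the expectation rests only on the two values given. The gap between compound 2 and compound 1 shows that changes around this amine can move the number considerably, and it is expected that the step of a 4.4-fold higher number from compound 2 to compound 3 (0.64 log units; beyond the scatter) leads to a weaker inhibitor, beyond the scatter. For compound 3 the estimated value in this assay is 100 nM, with a range from 25 nM to 400 nM.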

Compound 3, half-maximal inhibitory concentration: 36.3 nM
The estimate for compound 3 lay 2.8-fold (0.44 log units) above the measured number; the measured number falls inside the stated range.
By their numbers in this assay, from the lowest: compounds 2 and 3 (each within the scatter of the next); then compound 1.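

In this assay, exchanging the 2-(((pyridin-4-yl)methyl)amino)ethyl group for a group carrying a six-membered non-aromatic ring with 1 hetero atom gives a 1.6-fold higher number from compound 2 to compound 3 (0.20 log units; within the scatter), so the two compounds cannot be told apart by this read-out. At this place, on a saturated chain carbon, two bonds along the chain from an amine nitrogen, a six-membered aromatic ring is therefore not required for a number in this range, at least in this single pair. Nothing given here bears on why the two groups read alike.

The compounds shown leave open how far this place tolerates change, for instance with a piperidine ring, a carboxylic acid or a plain primary amine at the end of the chain. They also leave open whether a longer chain would keep the number within the scatter of these two values.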